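Trifluoromethoxy for cyano with stability at the limit

This account rests on a few compounds, and the source may have more. Where it says the series, first, only, none or still open, it means among the compounds named here.

In an ADME assay on microsomes from liver (Homo sapiens) for metabolic stability, read by LC-MS, with NADPH named in the record, with a stated time of 60 min, tested at 1 uM, in the absence of a further agent (a higher number here means that more of the compound is left, a lower number that less of the compound is left), compound 1 `CC(=O)N[C@@H]1CCN(c2cc(C)nn3c(-c4ccccc4)c(C)nc23)C1` gives > 95% as a limit of the assay. Compound 2 `CC(=O)N[C@@H]1CCN(c2cc(C)nn3c(-c4ccc(C#N)cc4)c(C)nc23)C1` gives > 95% which is likewise a limit and not a number. Compound 3 `CC(=O)N[C@@H]1CCN(c2cc(C)nn3c(-c4ccc(OC(F)(F)F)cc4)c(C)nc23)C1` carries trifluoromethoxy in place of cyano on an aromatic carbon and has not yet been measured. Among the measured compounds shown here, the only measured step that bears on this is a step that the two limits leave unreadable from compound 1 to compound 2 and its size cannot be read. The evidence is the limit of > 95% in this assay, at which 2 of the 2 values shown sit, and it gives no direction. No change beyond the scatter is therefore expected in this assay and the estimated step is a number at least 3 percentage points lower from compound 2 to compound 3 (that floor lies within the scatter) for now. Compound 3 is expected at 92% with a likely range from 78% to 100% in the same read-out.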

Compound 3, percent of the compound remaining: > 95%
Compound 3 gave a limit, no number; the forecaster's own chance of this, stated with the estimate: 50%; middle value at least 3 percentage points from the limit.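

Among the compounds shown here, compound 1, compound 2 and compound 3 all stand at a limit in this assay, so no step among them can be read: the limit of > 95% in this assay, at which 3 of the 3 values shown sit. The compounds shown leave open whether hydrogen, cyano or trifluoromethoxy on that aromatic carbon changes the percent of compound remaining.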